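Swapping amino for isobutoxy on a pyrimidinone ester

The source may hold more compounds than are shown below. What is called first, only, known or untested is meant among the compounds shown, and "the series" means these compounds.

Within the data shown here, compound 1, `Nc1ccccc1-c1ncc(C(=O)O)c(=O)[nH]1`, is the only compound here with a measured number: in a functional assay on the whole organism (strain Sprague-Dawley) for inhibition, with Rattus norvegicus as the target, with a stated time of 10 min (a higher number here means that more compound is needed for the effect, a lower number that less compound is needed), compound 1 gives 50 mg/kg. Compound 2, `CCOC(=O)c1cnc(-c2ccccc2N)[nH]c1=O`, shares the core of compound 1 but carries an ethyl ester in place of the acid; in this assay compound 2 gives "not determined" (no result reported), so it offers no point of comparison of its own. Compound 3, `CCOC(=O)c1cnc(-c2ccccc2OCC(C)C)[nH]c1=O`, is the next compound and has not yet been measured.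

The change from compound 2 to compound 3 is isobutoxy in place of amino on an aromatic carbon. Compound 2 has no number. Nothing on the measured side allows the size of this step to be read off, and the only anchor is the result for compound 1. The step is therefore expected to fall somewhere around that anchor, with no clear direction that can be called beyond the scatter.

Compound 3 is estimated to need about 40 mg/kg in this assay, with a range expected from 10 mg/kg to 150 mg/kg.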

Compound 3, dose for 50% inhibition: 3 mg/kg
Estimate against measurement, compound 3: 13-fold (1.12 log units) above; the measured number lies below the stated range.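

Among these compounds, compound 2 has no number in this assay, so no step from compound 2 to compound 3 can be read. From the compounds shown here alone, what swapping amino for isobutoxy does on its own to the dose needed therefore stays open, with the ester held the same. Nothing measured here offers an explanation for the result for compound 3.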